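This account rests on a few compounds, and the source may have more. Where it says the series, first, only, none or still open, it means among the compounds named here.

Measured in an ADME assay on NCI-H630 cells (Homo sapiens) for cytotoxicity, read by MTT assay, with a stated time of 72 h; on this read-out higher numbers stand for lower toxicity in this test and lower numbers for higher toxicity in this test:
compound 1 `O=C(NCc1ccc(F)cc1)c1cc(S(=O)(=O)N2CCCCC2)cc(O)c1O`: 13000 nM
compound 2 `CNS(=O)(=O)c1cc(O)c(O)c(C(=O)NCc2ccc(F)cc2)c1`: > 40000 nM

Within the data shown here, compound 1 holds the only actual number so far. The entry for compound 2, > 40000 nM, is a limit of the assay and not a number.

Compound 3 `O=C(NCc1cccs1)c1cc(S(=O)(=O)N2CCCCC2)cc(O)c1O` departs from compound 1 at a different place: thiophen-2-yl in place of 4-fluorophenyl on a saturated chain carbon bound to an amide-type nitrogen. Among the measured compounds shown here, the one measured step, an at least 3.0-fold higher number from compound 1 to compound 2 (0.48 log units; beyond the scatter), puts methylamino in place of piperidin-1-yl on a sulfonyl sulfur, so it bears on this change only indirectly. For the measured compounds named here, no measured step covers the new change, and no shift beyond the scatter is expected in this assay. The expected change is no change at the digits printed from compound 1 to compound 3 (within the scatter). For compound 3 the estimated value is 13000 nM, with an expected range of 5000 nM to 32000 nM.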

Compound 3, half-maximal cytotoxic concentration: > 40000 nM
Compound 3: a limit, no number; the forecaster's own chance of this, stated with the estimate: 12%; middle value at least 3.0-fold (0.48 log units) away from the limit.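

In this assay, the place on the saturated chain carbon bound to an amide-type nitrogen now has a measured step of its own: thiophen-2-yl in place of 4-fluorophenyl gives an at least 3.0-fold higher number from compound 1 to compound 3 (0.48 log units; beyond the scatter). The number for compound 1 therefore responds to a change at this place as well as to the change on the sulfonyl sulfur, which gave an at least 3.0-fold higher number from compound 1 to compound 2 (0.48 log units; beyond the scatter). Compound 3 gives > 40000 nM, which is a limit and not a number, and the two steps cannot be ranked against each other: the limit of > 40000 nM in this assay, at which 2 of the 3 values shown sit.

Still open, going by these compounds, is how a phenyl group without fluorine, a furan-2-yl group or a longer chain at this place would read against compound 1. Among these compounds, with compound 1 the only one holding a number, the full size of either step also remains unknown.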